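The compounds below may be only part of what the source reports. "The series", "measured", "known", "first", "only" and "open" are said of these compounds alone.

In a functional assay on HT-29 cells (Homo sapiens) for inhibition, read by sulforhodamine B assay, with a stated time of 48 h (on this read-out higher numbers stand for weaker inhibition of growth and lower numbers for stronger inhibition of growth), compound 1 (`CC1(/C=C/c2ccccc2C(F)(F)F)C=CC(=O)O1`) gives 15800 nM and compound 2 (`CC1(/C=C/c2ccc(C(F)(F)F)cc2)C=CC(=O)O1`) gives 12300 nM while compound 3 (`COc1c(O)ccc(/C=C/C2(C)C=CC(=O)O2)c1OC`) gives 19100 nM on the same read-out. Compound 2 sits within the scatter of both other compounds, so these numbers set no order among the three. Among the compounds with values here, no pair of measured compounds differs in one place only, so the effect of a single change has not yet been seen directly. Compound 4 (`COc1ccc(/C=C/C2(C)C=CC(=O)O2)cc1`) departs from compound 2 by one change, methoxy in place of trifluoromethyl on an aromatic carbon with methoxy in place of trifluoromethyl on an aromatic carbon para to a group of 9 heavy atoms. Compound 3 also carries methoxy on its aromatic ring and gives 19100 nM within the scatter of compound 2. On that evidence the step of a 1.2-fold higher number from compound 2 to compound 4 (0.09 log units; within the scatter) is expected to stay within the scatter, with no firm direction. For compound 4 the estimated value is 15000 nM in this assay with an expected range from 7500 nM to 30000 nM on this read-out.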

Compound 4, concentration for total growth inhibition: 92900 nM
The estimate for compound 4 lay 6.2-fold (0.79 log units) below the measured number; measured number outside the range, above it.
By their numbers in this assay, from the lowest: compounds 2, 1 and 3 (each within the scatter of the next); then compound 4.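

Within the data shown here, the step of a 7.6-fold higher number from compound 2 to compound 4 (0.88 log units; beyond the scatter) in this assay is the first single-place comparison and the first difference beyond the scatter. It shows that the aromatic carbon para to a group of 9 heavy atoms is not indifferent to its substituent: with methoxy in place of trifluoromethyl, the number moves towards weaker inhibition of growth. No measurement shown explains this shift.

A single pair cannot separate what is lost with trifluoromethyl from what is brought by methoxy at this place. From the compounds shown here alone, whether a plain hydrogen, a chlorine, a nitrile or an amine on this aromatic carbon would stay within the scatter of compound 2, stay within the scatter of compound 4, or fall elsewhere remains open.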